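The source may hold more compounds than are shown below. What is called first, only, known or untested is meant among the compounds shown, and "the series" means these compounds.

Compound 1 `CCN(CC)CCC(=O)OC1CC2(N(C)C)CC(c3ccccc3)C1C(c1ccccc1)C2`: 23600 nM
Compound 2 `CCN(CC)CCC(=O)OC1CC2(N3CCCC3)CC(c3ccccc3)C1C(c1ccccc1)C2`: 19200 nM

Both compounds were measured in an ADME assay on L6 cells (Rattus norvegicus) for cytotoxicity; on this read-out higher numbers stand for weaker inhibition and lower numbers for stronger inhibition. For the measured compounds named here, compound 2 stands within the scatter of compound 1, the only other measured compound, so the pair offers no real separation on these numbers. The next compound, compound 3 `CCN(CC)CCC(=O)OC1CC2(N3CCCCC3)CC(c3ccccc3)C1C(c1ccccc1)C2`, is altered at the same saturated ring carbon, with piperidin-1-yl in place of pyrrolidin-1-yl on a saturated ring carbon. Going by the values given here, only one measured step bears on this change. It is the replacement of dimethylamino by pyrrolidin-1-yl at that carbon, a 1.2-fold lower number from compound 1 to compound 2 (0.09 log units; within the scatter), and it stayed within the scatter. Among the compounds with values here, a single step is thin evidence, and no measured compound yet carries piperidin-1-yl. Even so, the one available precedent gives no reason to expect a shift in either direction in this assay beyond the scatter. The expected change is therefore small, with an estimated 1.0-fold lower number from compound 2 to compound 3 (0.00 log units; within the scatter). Compound 3 is estimated at 19000 nM, with an expected range from 10000 nM to 36000 nM.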

Compound 3, half-maximal inhibitory concentration: 22900 nM
The estimate for compound 3 lay 1.2-fold (0.08 log units) below the measured number; low and high end bracket the measured number.
By their numbers in this assay, from the lowest: compounds 2, 3 and 1 (each within the scatter of the next).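

Replacing pyrrolidin-1-yl by piperidin-1-yl on this saturated ring carbon gives a 1.2-fold higher number from compound 2 to compound 3 (0.08 log units; within the scatter) in this assay, and the direct comparison of piperidin-1-yl with dimethylamino gives a 1.0-fold lower number from compound 1 to compound 3 (0.01 log units; within the scatter). For the compounds shown here, the position now carries three different groups, two of them rings of different size, and all three compounds stand within the scatter of one another, which extends what the single earlier step could show for this one carbon. No supporting data explain why the three numbers stay so close.

The compounds shown do not reveal whether a group of another kind at this carbon, such as morpholin-4-yl with its ring oxygen, a primary amine or a carboxylic acid, would move the number beyond the scatter. On these data alone, they also leave open how far the read-out depends on the parts all three compounds share, since the ((2-(diethylamino)ethyl)carbonyl)oxy group and both phenyl groups stay the same throughout, and a shorter chain in that ester or a substituted phenyl ring remains untested in this account.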